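A few compounds are considered here, and "the series" means these few. Any claim that something is new, unique, unknown or untested is made for them only; others in the source may bear on it.

Measured in an ADME assay on microsomes from liver (Homo sapiens) for metabolic stability, read by LC-MS, using NADPH, with a stated time of 10 min, tested at 10 uM; on this read-out lower numbers stand for a shorter-lived compound and higher numbers for a longer-lived compound:
- compound 1 `Nc1ncnc2c1c(Oc1cc(C(F)(F)F)ccn1)nn2C1CC1`: > 2.41 h (a limit, not a number)
- compound 2 `CC(C)(C)n1nc(Oc2cc(Cl)ccn2)c2c(N)ncnc21`: 1 h
- compound 3 `Nc1ncnc2c1c(Oc1cccc(C(F)(F)F)c1)nn2[C@H]1C[C@H](O)C1`: 1.25 h

Compound 1 stands at the limit of > 2.41 h in this assay, at which 1 of the 3 values shown sits. The numbers for compound 2 and compound 3 lie within the usual scatter of each other.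

The next compound to be read is compound 4 `CO[C@H]1CC[C@H](n2nc(Oc3cc(C(F)(F)F)ccn3)c3c(N)ncnc32)CC1`, with 4-methoxycyclohexyl in place of cyclopropyl on an aromatic nitrogen. Going by the values given here, no measured pair isolates this change, so the expectation is loose. In this assay a clear step down is expected, towards the numbers of compound 2 at 1 h and compound 3 at 1.25 h. The step expected is an at least 2.0-fold lower number from compound 1 to compound 4 (0.30 log units; that floor lies within the scatter). For compound 4 the estimated half-life is 1.2 h, with an expected range of 0.5 h to 2.6 h.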

Compound 4, half-life: > 2.41 h
Compound 4: no number, only a limit (the forecaster's own chance of this, stated with the estimate: 15%); middle value at least 2.0-fold (0.30 log units) from the limit.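

Going by these compounds alone, compound 4 gives > 2.41 h in this assay, a limit and not a number, as is the value of compound 1, and no step between the two can be read. The compounds shown leave open what 4-methoxycyclohexyl in place of cyclopropyl on an aromatic nitrogen does to half-life.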